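This account rests on a few compounds, and the source may have more. Where it says the series, first, only, none or still open, it means among the compounds named here.

Series notes. Among the measured compounds shown here, in a functional assay on the whole organism for inhibition of sodium-dependent dopamine transporter (Mus musculus) (a lower number here means that less compound is needed, a higher number that more compound is needed for the effect), the three measured members of the shared core cover a modest range. Compound 1 `Cc1ccc(C2CN(C)Cc3c(N)cccc32)cc1` gives about 22 mg/kg. Compound 2 `CCOC(=O)Nc1cccc2c1CN(C)CC2c1ccc(F)cc1` gives 4.6 mg/kg. Compound 3 `CCCCOC(=O)Nc1cccc2c1CN(C)CC2c1ccccc1` gives 12 mg/kg. Compound 3 thus stands second highest of the three numbers: its gap to compound 1 lies within the scatter, while compound 2 reads lower by a margin beyond it. The unmeasured compound 4 `CN1Cc2c(NC(=O)CN3CCCC3)cccc2C(c2ccccc2)C1` differs from compound 3 in one place: (pyrrolidin-1-yl)methyl in place of butoxy on a carbonyl carbon. No measured pair in the set carries this change, so nothing shown supports a direction; the expected step is no change at the digits printed from compound 3 to compound 4 (within the scatter), a move not beyond the scatter either way. Compound 4 is accordingly estimated at 12 mg/kg, with a range from 5 mg/kg to 30 mg/kg.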

Compound 4, dose for half-maximal effect: 45 mg/kg
Compound 4: middle estimate off by 3.8-fold (0.57 log units), on the low side; measured number above the stated range.
By their numbers in this assay, from the lowest: compound 2; then compounds 3 and 1 (each within the scatter of the next); then compound 4.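

In this assay, among the compounds shown here, (pyrrolidin-1-yl)methyl in place of butoxy on a carbonyl carbon gives a 3.8-fold higher number from compound 3 to compound 4 (0.57 log units; beyond the scatter), the first one-place step, so this position is sensitive to the group it carries. Nothing in hand bears on why the number moves.

Still open, as far as these compounds go, is whether the step follows the nitrogen of the entering group, its ring, or the loss of the butoxy oxygen. A plain pentyl chain or an open-chain diethylaminomethyl group on the same carbonyl would separate these readings.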